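Swapping the aryl group on the sulfonamide nitrogen

The source may report more compounds than this note shows. Statements on the series, on what has been measured and on what is new or still open speak of the compounds shown alone.

Measured so far:
Compound 1, `CCN(CC)C(=O)CN(c1cc(C(C)C)ccc1Cl)S(=O)(=O)c1ccc(OC)c(OC)c1`, gives 888 nM.
Compound 2, `CCN(CC)C(=O)CN(c1cc(N(C)C)ccc1C#N)S(=O)(=O)c1ccc(OC)c(OC)c1`, gives 166 nM.

Both numbers come from a functional assay on CHO cells for inhibition of Orexin/Hypocretin receptor type 1 (Homo sapiens), read by FLIPR and calcium flux; a lower number here means a stronger inhibitor, a higher number a weaker inhibitor. Within the data shown here, compound 2 stands as the lower of the two numbers, and its only neighbour is compound 1, whose value lies a 5.3-fold lower number from compound 1 to compound 2 (0.73 log units; beyond the scatter) away in the direction of compound 2. That single step, a change of the aryl group on the sulfonamide nitrogen, is the whole of the experience here.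

Compound 3, `CCN(CC)C(=O)CN(c1cc(Cl)ccc1N(C)C)S(=O)(=O)c1ccc(OC)c(OC)c1`, is not yet measured. It differs from compound 2 in the same place: 5-chloro-2-(dimethylamino)phenyl in place of 2-cyano-5-(dimethylamino)phenyl on a sulfonamide nitrogen. Among the measured compounds shown here, the one measured step shows that changing this aryl group can move the number beyond the scatter, but it involved a different pair of groups, so it points to no direction for the present swap. The expectation is therefore cautious: a step of about a 2.1-fold higher number from compound 2 to compound 3 (0.32 log units; beyond the scatter) toward a somewhat higher number, with a wide range that includes no change beyond the scatter. Compound 3 is expected to give roughly 350 nM in this assay, between 120 nM and 1100 nM.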

Compound 3, half-maximal inhibitory concentration: 4880 nM
For compound 3 the middle estimate is 14-fold (1.14 log units) below the measured one; measured number outside the range, above it.
By their numbers in this assay, from the lowest: compound 2; then compound 1; then compound 3.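

In this assay, this swap shows that the aryl group on the sulfonamide nitrogen can carry a much larger change than the first step revealed: the replacement gives a 29-fold higher number from compound 2 to compound 3 (1.47 log units; beyond the scatter) and makes compound 3 the weakest inhibitor of the three. A dimethylamino group on the ring does not by itself secure a low number, as compound 2 and compound 3 both carry one, and the change from the group without it gives a 5.5-fold higher number from compound 1 to compound 3 (0.74 log units; beyond the scatter) in the unfavourable direction. Nothing available explains why these aryl groups differ so strongly.

The step from 2-cyano-5-(dimethylamino)phenyl to 5-chloro-2-(dimethylamino)phenyl removes the nitrile, brings in a chlorine and moves the dimethylamino group at once, and the compounds shown do not separate these three changes. As far as these compounds go, it also remains open how a fluorine atom or a methoxy group in place of that chlorine, or a morpholine in place of the dimethylamino group, would behave.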